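Working notes: oxolan-2-yl in place of isopropyl

The source may hold more compounds than are shown below. What is called first, only, known or untested is meant among the compounds shown, and "the series" means these compounds.

Measured so far in a physicochemical assay for lipophilicity, at pH 7.4; a higher number here means a more lipophilic compound, a lower number a more polar compound
Compound 1 `Cc1cc(C(=O)Nc2ccc(F)cc2)nn1Cc1cc(Cl)ccc1OCc1ccccc1` gives 3
Compound 2 `Cc1cc(C(=O)NCc2ccncc2)nn1Cc1cc(Cl)ccc1OCc1ccccc1` gives > 3.7 as a limit
Compound 3 `Cc1cc(NC(=O)C(C)C)nn1Cc1cc(Cl)ccc1OCc1ccccc1` gives > 3.7 as a limit

Compound 3 has only a limit > 3.7 and the expectation starts from it. Compound 4 `Cc1cc(NC(=O)C2CCCO2)nn1Cc1cc(Cl)ccc1OCc1ccccc1` carries oxolan-2-yl in place of isopropyl on a carbonyl carbon and only the entering group holds a hydrogen-bond acceptor. The measured steps reaching compound 3 are a number at least 0.70 log units higher from compound 1 to compound 3 (beyond the scatter) and a step that the two limits leave unreadable from compound 2 to compound 3 and neither makes this exchange, so the size remains uncertain. The expected change is a number at least 0.20 log units lower from compound 3 to compound 4 (that floor lies within the scatter) in this assay as a modest estimated fall. For compound 4 the estimated value is 3.5 with 3 to 4 as the expected range.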

Compound 4, distribution coefficient: > 3.7
Compound 4 was reported as a limit (the forecaster's own chance of this, stated with the estimate: 35%); middle value at least 0.20 log units from the limit.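

In this assay compound 4 gives > 3.7, which is a limit and not a number. Oxolan-2-yl on this carbonyl carbon, with its hydrogen-bond acceptor, thus gives no reading under the limit, and the comparison with compound 1 is a number at least 0.70 log units higher from compound 1 to compound 4 (beyond the scatter). The steps to compound 4 from compound 2 and compound 3 cannot be read, since all three sit at one limit: the limit of > 3.7 in this assay, at which 3 of the 4 values shown sit.

As far as these compounds go, the true size of the change from isopropyl to oxolan-2-yl stays open. Also open, from the compounds shown here alone, is whether a group carrying an amine or a carboxylic acid on this carbonyl carbon would give a reading under the limit.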